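The source may hold more compounds than are shown below. What is called first, only, known or untested is meant among the compounds shown, and "the series" means these compounds.

Compound 1 `COc1ccc(/C=C/C[C@H]2C[C@@H]([C@@H](O)c3ccccc3)CO[C@@H]2c2ccccc2)cc1` gives 9010 nM in a functional assay on HL-60 cells (Homo sapiens) for cytotoxicity, read by WST assay, with a stated time of 48 h; a lower number here means a stronger inhibitor, a higher number a weaker inhibitor.
Compound 2 `COc1ccccc1/C=C/C[C@H]1C[C@@H]([C@@H](O)c2ccccc2)CO[C@@H]1c1ccccc1` gives 10100 nM.
Compound 3 `O[C@@H](c1ccccc1)[C@H]1CO[C@H](c2ccccc2)[C@@H](C/C=C/C2CCCCC2)C1` gives 6260 nM.

All three compounds share a core and differ only in the group at the end of the side chain. Within this small set, compound 1 holds the second highest number of the three: the change to the nearest value is a 1.1-fold higher number from compound 1 to compound 2 (0.05 log units; within the scatter), and the change to the furthest value is a 1.4-fold lower number from compound 1 to compound 3 (0.16 log units; within the scatter). Going by the values given here, the third pairing, a 1.6-fold lower number from compound 2 to compound 3 (0.21 log units; within the scatter), is likewise within the scatter, so swapping one end group for another has not moved the numbers so far.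

Compound 4 `C=CC[C@H]1C[C@@H]([C@@H](O)c2ccccc2)CO[C@@H]1c1ccccc1` has not yet been measured. It differs from compound 1 in this way:

vinyl in place of 2-(4-methoxyphenyl)ethenyl on a saturated chain carbon bound to a saturated ring carbon

Among the compounds with values here, no measured step bears directly on cutting the chain down to vinyl; the measured steps only exchange one end group for another of similar size, and each of those fell within the scatter. Because the available steps such as a 1.4-fold lower number from compound 1 to compound 3 (0.16 log units; within the scatter) show little sensitivity to the end group, the expectation for compound 4 is a number near or somewhat above that of compound 1, with an estimated step of a 1.7-fold higher number from compound 1 to compound 4 (0.22 log units; within the scatter). The estimate for compound 4 is 15000 nM, within a range from 5000 nM to 45000 nM.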

Compound 4, half-maximal inhibitory concentration: 36000 nM
The estimate for compound 4 lay 2.4-fold (0.38 log units) below the measured number; measured number inside the range.
By their numbers in this assay, from the lowest: compounds 3, 1 and 2 (each within the scatter of the next); then compound 4.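

Swapping one end group for another of similar size left the numbers within the scatter, but removing the ring-bearing end and leaving only vinyl on the saturated chain carbon bound to a saturated ring carbon has a visible effect in this assay: there is a 4.0-fold higher number from compound 1 to compound 4 (0.60 log units; beyond the scatter) and a 3.6-fold higher number from compound 2 to compound 4 (0.55 log units; beyond the scatter) as well as a 5.8-fold higher number from compound 3 to compound 4 (0.76 log units; beyond the scatter). All three modest steps run the same way, so at this position, in these four compounds, keeping one of the larger end groups counts for more than which of them is present. No available evidence explains this loss of activity.

The change removes a ring and shortens the chain together, so the compounds shown cannot tell these two apart; a longer chain of plain carbon with no ring could do so. From the compounds shown here alone, how an amine or a carboxylic acid at the chain end would behave also remains open.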